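Trimethoxy series: from compound 3 to compound 4

A few compounds are considered here, and "the series" means these few. Any claim that something is new, unique, unknown or untested is made for them only; others in the source may bear on it.

Measured in a functional assay on L1210 cells (Mus musculus) for cytotoxicity, read by MTT assay, with a stated time of 24 h; a lower number here means a stronger inhibitor, a higher number a weaker inhibitor:
- compound 1 `COc1cc(C(=O)/C=C/c2ccc(Cl)c(Cl)c2)cc(OC)c1OC`: 44000 nM
- compound 2 `COc1cc(C(=O)/C=C/c2ccc(Cl)cc2)cc(OC)c1OC`: 44500 nM
- compound 3 `COc1cc(C(=O)/C=C/c2ccc(Br)cc2)cc(OC)c1OC`: > 100000 nM (a limit, not a number)

Compound 3 has no numerical value and stands at the limit of > 100000 nM in this assay, at which 1 of the 3 values shown sits. Compound 4 `COc1cc(C(=O)/C=C/c2ccc(C)o2)cc(OC)c1OC` has 5-methylfuran-2-yl in place of 4-bromophenyl on a double-bonded chain carbon bound to a double-bonded chain carbon.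

Within the data shown here, three measured steps concern the group on that carbon. Two are modest: an at least 2.2-fold higher number from compound 1 to compound 3 (0.35 log units; beyond the scatter) and an at least 2.2-fold higher number from compound 2 to compound 3 (0.35 log units; beyond the scatter). The third, a 1.0-fold higher number from compound 1 to compound 2 (0.00 log units; within the scatter), stays within the scatter. None of them tests a furan, so the evidence is indirect. Since compound 3 sits at a limit, any measurable value for compound 4 would lie on the lower side, and a modest step to a lower number is expected in this assay, back toward compound 1 and compound 2. A second limit remains possible.

The expected change is an at least 2.2-fold lower number from compound 3 to compound 4 (0.34 log units; beyond the scatter).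

For compound 4 the estimate is 45000 nM, with an expected range of 15000 nM to 100000 nM.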

Compound 4, half-maximal inhibitory concentration: 46500 nM
Beside the measured number, compound 4's estimate is 1.0-fold (0.01 log units) below it; the measured number falls inside the stated range.
By their numbers in this assay, from the lowest: compounds 1, 2 and 4 (each within the scatter of the next). At a limit, above all of these: compound 3.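

In this assay, among these compounds, 5-methylfuran-2-yl in place of 4-bromophenyl gives an at least 2.1-fold lower number from compound 3 to compound 4 (0.33 log units; beyond the scatter) on a double-bonded chain carbon bound to a double-bonded chain carbon, the first change at this place that leads away from a limit to a number. The five-membered aromatic ring also stands level with both chlorinated phenyl groups, with a 1.0-fold higher number from compound 2 to compound 4 (0.02 log units; within the scatter) and a 1.1-fold higher number from compound 1 to compound 4 (0.02 log units; within the scatter) as its steps, so among the compounds shown a six-membered ring of carbon only is not needed here to keep the reading of compounds 1 and 2. On these data alone, compound 3 remains a limit, not a number, so the true size of its step stays unknown: the limit of > 100000 nM in this assay, at which 1 of the 4 values shown sits.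

As far as these compounds go, whether the ring oxygen or the methyl of compound 4 matters stays open, with furan-2-yl lacking the methyl or a thiophene as direct tests. Also open, from the compounds shown here alone, is whether any group here, such as a pyridine or a phenyl carrying an amine or a carboxylic acid, gives a number lower than compounds 1, 2 and 4 by more than the scatter.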